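This account rests on a few compounds, and the source may have more. Where it says the series, first, only, none or still open, it means among the compounds named here.

Measured compounds so far:
- compound 1, `O=C(N/N=C/c1ccccc1)Nc1ccc(Oc2ccnc3[nH]ccc23)c(F)c1`: 640 nM
- compound 2, `O=C(N/N=C/c1cccc(Br)c1)Nc1ccc(Oc2ccnc3[nH]ccc23)c(F)c1`: 660 nM
- compound 3, `O=C(N/N=C/c1ccccc1)Nc1ccc(Oc2ccnc3[nH]ccc23)cc1`: 750 nM

All three were tested in a functional assay on HepG2 cells (Homo sapiens) for antiproliferative activity, read by MTT assay, with a stated time of 72 h; on this read-out lower numbers stand for stronger inhibition and higher numbers for weaker inhibition. The series rests on a shared core that carries an aryl hydrazone, and two compounds differ from compound 1 in a single place each. Compound 2 differs from compound 1 by bromo in place of hydrogen on an aromatic carbon, and that change made a step of a 1.0-fold higher number from compound 1 to compound 2 (0.01 log units; within the scatter). Compound 3 differs from compound 1 by hydrogen in place of fluoro on an aromatic carbon, with a step of a 1.2-fold higher number from compound 1 to compound 3 (0.07 log units; within the scatter). Compound 2 and compound 3 were not compared directly as a step, and their values lie close to each other.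

The unmeasured compound 4, `O=C(N/N=C/c1ccc(Br)cc1)Nc1ccc(Oc2ccnc3[nH]ccc23)cc1`, differs from compound 3 by bromo in place of hydrogen on an aromatic carbon. This is the same kind of change that turned compound 1 into compound 2, and among the compounds shown it occurs twice in all. It is not the same change: in compound 2 the bromo sits meta to a large group, whereas in compound 4 it sits para to a large group. The two cores differ as told by hydrogen in place of fluoro on an aromatic carbon.

For compound 4 the expected step in this assay is no change at the digits printed from compound 3 to compound 4 (within the scatter), beside the earlier one, resting on the observation that the step of a 1.0-fold higher number from compound 1 to compound 2 (0.01 log units; within the scatter) from compound 1 to compound 2 stayed within the scatter. Compound 4 is therefore estimated at 750 nM, with a range from 400 nM to 1400 nM.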

Compound 4, half-maximal inhibitory concentration: 1000 nM
Beside the measured number, compound 4's estimate is 1.3-fold (0.12 log units) below it, and the stated range covers the measured number.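

Bromo in place of hydrogen on an aromatic carbon has now been read on two cores in this assay, and the two steps do not differ beyond what repeated measurements would give: the same change on two cores in this assay, a 1.0-fold higher number (0.01 log units; within the scatter) from compound 1 to compound 2 and a 1.3-fold higher number (0.12 log units; within the scatter) from compound 3 to compound 4, 1.3-fold (0.11 log units) apart, within the scatter of two such steps. For the compounds shown here, both the new step, a 1.3-fold higher number from compound 3 to compound 4 (0.12 log units; within the scatter), and the earlier one, a 1.0-fold higher number from compound 1 to compound 2 (0.01 log units; within the scatter), lie within the scatter, so on the core with fluoro and on the core without it, this change gave no step that could be told from scatter. Going by these compounds alone, this does not show that the change carries over as a rule: only two pairs are at hand, neither step has a size that could be transferred, and the bromo sits para to a large group in compound 4 but at another place on the ring in compound 2, so the core and the place of the bromo vary together across the two steps.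

The compounds shown leave open whether bromo at one and the same place would read alike on both cores. They also leave open whether another group on this ring, such as an amine, a carboxylic acid or a longer chain, would give a step beyond the scatter.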